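Fluoro to methyl on compound 2

A few compounds are considered here, and "the series" means these few. Any claim that something is new, unique, unknown or untested is made for them only; others in the source may bear on it.

For the measured compounds named here, in a functional assay on NCI-H460 cells (Homo sapiens) for cytotoxicity, read by sulforhodamine B assay, with a stated time of 3 days (on this read-out lower numbers stand for stronger inhibition and higher numbers for weaker inhibition), compound 1 (`O=CC1C(=O)N(Cc2ccc(Cl)cc2)c2cc(Cl)ccc21`) gives 18200 nM and compound 2 (`OCc1cn(Cc2cccc(F)c2)c2ccccc12`) gives 40 nM as the lower of only two numbers so far, a gap well beyond the scatter. Going by the values given here, the two structures differ in more than one place, so this gap cannot be assigned to any single group, and no measured pair isolates one change.

Next in line is compound 3 (`Cc1cccc(Cn2cc(CO)c3ccccc32)c1`), which departs from compound 2 in a single place: methyl in place of fluoro on an aromatic carbon. Among the compounds with values here, with no measured step to draw on, the expectation rests on the structural change alone, an exchange of one small substituent for another on an otherwise identical structure. The expected step in this assay is a 1.3-fold higher number from compound 2 to compound 3 (0.10 log units; within the scatter) and is estimated to stay within the scatter, so no clear change in either direction is expected. For compound 3 the estimated value is 50 nM with an expected range from 15 nM to 170 nM in repeated measurements.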

Compound 3, half-maximal inhibitory concentration: 31 nM
The estimate for compound 3 lay 1.6-fold (0.21 log units) above the measured number; measured number inside the range.
By their numbers in this assay, from the lowest: compounds 3 and 2 (each within the scatter of the next); then compound 1.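

In this assay, for the compounds shown here, methyl in place of fluoro on an aromatic carbon, meta to a large group, gives the first step that isolates one change: a 1.3-fold lower number from compound 2 to compound 3 (0.11 log units; within the scatter). At this position, the two substituents, each of one heavy atom and with no hydrogen-bond donors or acceptors, cannot be told apart on this read-out, so the low number of compound 2 does not depend on fluoro specifically. No independent data bear on why the exchange leaves the read-out within the scatter.

The compounds shown leave open how far this position tolerates change, as a single exchange between two one-atom substituents says nothing about an amine, a carboxylic acid or a longer chain at the same aromatic carbon. They also leave open whether methyl and fluoro would remain interchangeable elsewhere on the six-membered aromatic ring, and the series still has no single-place step that explains the gap between compound 1 and the other two compounds.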